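The compounds below may be only part of what the source reports. "The series", "measured", "known", "first", "only" and "open" are said of these compounds alone.

Compound 1 `Cc1cc(Nc2cc(Cl)c(C)c(Cl)c2)nc(N)n1` gives > 63000 nM in an assay on cells for inhibition of S-adenosylmethionine decarboxylase proenzyme (Homo sapiens), read by mass spectrometry, at pH 7.2 (a higher number here means a weaker inhibitor, a lower number a stronger inhibitor), a limit of the assay.
Compound 2 `Cc1cc(Nc2cc(Cl)c(O)c(Cl)c2)nc(N)n1` gives > 180000 nM in this assay, likewise a limit.

Compound 2 thus stands at a limit rather than at a number, and so does compound 1. Among the compounds with values here, the single step between measured compounds, a step that the two limits leave unreadable from compound 1 to compound 2, cannot be read, as both ends sit at limits (the limit of > 180000 nM in this assay, at which 1 of the 2 values shown sits, and (the limit of > 63000 nM in this assay, at which 1 of the 2 values shown sits)). Compound 3 `Cc1cc(Nc2cc(Cl)c(N(C)C)c(Cl)c2)nc(N)n1` is not yet measured; it differs from compound 2 by dimethylamino in place of hydroxy on an aromatic carbon. No readable step bears on this change, and the two limits give no footing for a direction or a size. Compound 3 is therefore expected to show a limit again, with a value estimated at 150000 nM, within 30000 nM to 1000000 nM. The step of an at least 1.2-fold lower number from compound 2 to compound 3 (0.07 log units; that floor lies within the scatter) implied by this estimate is expected to be no more than nominal, since it runs from a limit.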

Compound 3, half-maximal inhibitory concentration: > 180000 nM
Compound 3: a limit, no number; the forecaster's own chance of this, stated with the estimate: 85%; at least 1.2-fold (0.07 log units) between middle value and limit.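

Compound 3 also stands at a limit, so neither the step to it from compound 2 nor the step to it from compound 1 can be read. The compounds shown leave open whether any group at this place on the shared core gives a readable number in this assay.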